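A few compounds are considered here, and "the series" means these few. Any claim that something is new, unique, unknown or untested is made for them only; others in the source may bear on it.

In a functional assay on L02 cells (Homo sapiens) for inhibition, read by Griess assay, with stated times of 1 h and 24 h (a higher number here means a weaker inhibitor, a lower number a stronger inhibitor), the measured compounds stand as follows.
Compound 1 `CNc1nc(/C=C/c2ccccc2)nc2ccsc12` gives > 1000000 nM, which is a limit of this assay and not a number.
Compound 2 `CC(C)c1ccc(Nc2nc(/C=C/c3ccco3)nc3ccsc23)cc1` gives > 1000000 nM, again a limit.
Compound 3 `CNc1nc(/C=C/c2cc(OC)c(OC)c(OC)c2)nc2ccsc12` gives > 1000000 nM, again a limit.

Compound 3 therefore stands at the limit, and the two other values shown sit there as well: the limit of > 1000000 nM in this assay, at which 3 of the 3 values shown sit. Among the compounds with values here, no step between measured compounds exists, so nothing here shows how any structural change moves this assay.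

Compound 4 `COc1ccc(CNc2nc(/C=C/c3cc(OC)c(OC)c(OC)c3)nc3ccsc23)cc1` differs from compound 3 by 4-methoxyphenyl in place of hydrogen on a saturated chain carbon bound to a nitrogen on an aromatic ring. Compound 2 likewise sits at a limit, so the shown values give no sign that an aromatic group on the amine side of this core brings the readout into the measurable range. On that basis, compound 4 is expected to behave like compound 3, with the step of a number no higher from compound 3 to compound 4 (the limit leaves the size open) expected to be none beyond the scatter, and most probably this assay will again return only a limit. The estimate for compound 4 is 1000000 nM, with a range from 100000 nM to 10000000 nM.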

Compound 4, half-maximal inhibitory concentration: > 1000000 nM
Compound 4 gave a limit, no number; the forecaster's own chance of this, stated with the estimate: 80%; the middle value lies on the limit itself.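

In this assay compound 4 gives > 1000000 nM, which is a limit and not a number. Compound 3 also stands at a limit, so no step can be read between compound 3 and compound 4. The compounds shown leave open which structural change, if any, would give a measurable value.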